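The source may hold more compounds than are shown below. What is called first, only, known or untested is meant among the compounds shown, and "the series" means these compounds.

Compound 1 `COc1ccc(/C=N/Nc2ncc(Cl)c(Nc3cccc(NC(=O)/C=C/CN(C)C)c3)n2)cc1` gives 4820 nM in an ADME assay on HT-29 cells (Homo sapiens) for inhibition, read by MTT assay, with a stated time of 72 h; a lower number here means a stronger inhibitor, a higher number a weaker inhibitor. Compound 2 `COc1ccc(/C(C)=N/Nc2ncc(Cl)c(Nc3cccc(NC(=O)/C=C/CN(C)C)c3)n2)cc1` gives 6830 nM in this assay.

On these two numbers compound 2 stands at the higher end, with compound 1 as its nearest neighbour; the step of a 1.4-fold higher number from compound 1 to compound 2 (0.15 log units; within the scatter) lies within the scatter, so the two compounds cannot be ranked against each other in this assay.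

Compound 3 `C/C(=N\Nc1ncc(Cl)c(Nc2cccc(NC(=O)/C=C/CN(C)C)c2)n1)c1cccnc1` has not yet been measured. It differs from compound 2 in one place: pyridin-3-yl in place of 4-methoxyphenyl on a carbon with a double bond to nitrogen. Among the compounds with values here, the only measured step available, the one from compound 1 to compound 2, concerns a group on a nitrogen on an aromatic ring and leaves the 4-methoxyphenyl ring itself untouched, so no measured step speaks directly to an exchange of that ring for pyridin-3-yl. With nothing in the numbers pointing either way, compound 3 is expected to sit close to compound 2, and the estimated step of a 1.0-fold higher number from compound 2 to compound 3 (0.01 log units; within the scatter) is taken as no change beyond the scatter. For compound 3 the estimate in this assay is 7000 nM, with a range from 2500 nM to 20000 nM.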

Compound 3, half-maximal inhibitory concentration: 9660 nM
Beside the measured number, compound 3's estimate is 1.4-fold (0.14 log units) below it; measured number inside the range.
By their numbers in this assay, from the lowest: compounds 1, 2 and 3 (each within the scatter of the next).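

Within the data shown here, on the carbon with a double bond to nitrogen, where the earlier compounds carried only 4-methoxyphenyl, the ring now has a first measured exchange: pyridin-3-yl in its place gives a step in this assay (a 1.4-fold higher number from compound 2 to compound 3 (0.15 log units; within the scatter)) that cannot be told apart from no effect. The step that spans both differences, on a nitrogen on an aromatic ring (a 2.0-fold higher number from compound 1 to compound 3 (0.30 log units; within the scatter)), is also printed as within the scatter, so compounds 1, 2 and 3 cannot be ranked against one another, even though a ring of carbon only has given way to a ring with a hetero atom and the heavy-atom count has changed. Nothing measured on these compounds bears on why this exchange leaves the number within the scatter.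

Whether any group on this carbon can move the number beyond the scatter stays open, since the compounds shown carry only 4-methoxyphenyl and pyridin-3-yl there. Pyridin-2-yl, pyridin-4-yl, a ring bearing a carboxylic acid or an amine, and a saturated ring such as cyclohexyl are not among them, so how far this tolerance extends cannot be said.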